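This account rests on a few compounds, and the source may have more. Where it says the series, first, only, none or still open, it means among the compounds named here.

Compound 1 `Nc1nc(C2CCCO2)nc2sc(Cc3ccccc3)cc12` and compound 2 `COc1ccccc1Cc1cc2c(N)nc(-c3nc(C)cs3)nc2s1` share a core that carries an amino group. Within the data shown here, in a functional assay on CHO-K1 cells for antagonist activity at adenosine receptor A1 (Homo sapiens), read by a beta-galactosidase reporter and cAMP accumulation, with stated times of 15 min and 6 h (a lower number here means a stronger inhibitor, a higher number a weaker inhibitor), compound 1 gives 2950 nM, the higher of the two numbers known so far, while compound 2 gives 186 nM in this assay, a gap well beyond the usual scatter of this kind of measurement. Compound 3 `N#Cc1cccc(-c2nc(N)c3cc(Cc4ccccc4)sc3n2)c1` differs from compound 1 in one place: 3-cyanophenyl in place of oxolan-2-yl on an aromatic carbon. An aromatic ring thus takes the position held in compound 1 by a non-aromatic ring, and compound 2, which also carries an aromatic ring at the corresponding point of its core, reaches the lower number of 186 nM. On that basis a fall in the number is expected; the estimated step is a 7.4-fold lower number from compound 1 to compound 3 (0.87 log units; beyond the scatter) in this assay. For compound 3 the expected value in this assay is 400 nM, within a range from 100 nM to 1500 nM.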

Compound 3, inhibition constant: 222 nM
The estimate for compound 3 lay 1.8-fold (0.26 log units) above the measured number; low and high end bracket the measured number.
By their numbers in this assay, from the lowest: compounds 2 and 3 (each within the scatter of the next); then compound 1.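

On the aromatic carbon between two ring nitrogen atoms, 3-cyanophenyl in place of oxolan-2-yl gives a 13-fold lower number from compound 1 to compound 3 (1.12 log units; beyond the scatter) in this assay. Compounds 1 and 3 differ in this one place only, so this pair shows that the group held here can by itself move the number well beyond the scatter, with the rest of the molecule unchanged. The exchange replaces a five-membered non-aromatic ring with a six-membered aromatic ring bearing a nitrile, and no measured evidence is available to explain the size of this step. The compounds shown leave open whether the aromatic ring or its nitrile accounts for the step, which an unsubstituted phenyl at this carbon would help separate. Going by these compounds, how an amine or a carboxylic acid on the same ring would read in this assay also remains open.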